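This account rests on a few compounds, and the source may have more. Where it says the series, first, only, none or still open, it means among the compounds named here.

Compound 1 `CC(C)[C@]1(C(=O)N2C[C@@H]3C[C@H]2CN3C(=O)OC(C)(C)C)CC[C@@H](NC2CCOCC2)C1`: > 2 h
Compound 2 `CC(C)[C@]1(C(=O)N2C[C@@H]3C[C@H]2CN3C(=O)C2CCCC2)CC[C@@H](NC2CCOCC2)C1`: > 2 h

In an in vitro ADME assay on microsomes from liver (Homo sapiens) for metabolic stability, tested at 1 uM (a lower number here means that the compound disappears faster, a higher number that the compound lasts longer), compound 2 gives > 2 h, which is a limit and not a number. Compound 1 is also reported only as a limit, and the limit of > 2 h in this assay, at which 2 of the 2 values shown sit, covers both compounds. Among the measured compounds shown here, the one measured step, a step that the two limits leave unreadable from compound 1 to compound 2, therefore has no size to carry forward.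

Compound 3 `CC(C)[C@]1(C(=O)N2C[C@@H]3C[C@H]2CN3C(=O)C2CCOCC2)CC[C@@H](NC2CCOCC2)C1` has not yet been measured. Its difference from compound 2 is oxan-4-yl in place of cyclopentyl on a carbonyl carbon. In words, oxan-4-yl stands in place of cyclopentyl on a carbonyl carbon. For the measured compounds named here, the measured step changed the same carbonyl carbon, with cyclopentyl in place of tert-butoxy, so it is the only guide, and a weak one.

No step beyond the scatter is expected in this assay, and another report as a limit is likely. The expected size is a step that the limit leaves unreadable from compound 2 to compound 3. For compound 3 the estimated half-life is 3 h, with an expected range of 1.5 h to 6 h.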

Compound 3, half-life: > 2 h
Compound 3 was reported as a limit; the forecaster's own chance of this, stated with the estimate: 75%; the middle value is on the limit's open side.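

In this assay compound 3 gives > 2 h, which is a limit and not a number. The steps from compound 1 and from compound 2 to compound 3 therefore cannot be read: the limit of > 2 h in this assay, at which 3 of the 3 values shown sit.

The compounds shown leave open whether the three half-lives differ at all, since none has a value beyond the limit.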